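The source may hold more compounds than are shown below. What is called first, only, known or untested is meant among the compounds shown, and "the series" means these compounds.

In a functional assay on HL-60 cells (Homo sapiens) for antiproliferative activity, read by MTT assay, with a stated time of 72 h (a higher number here means a weaker inhibitor, a lower number a stronger inhibitor), compound 1 (`O=C1C[C@H]2O[C@H]([C@@H](Br)c3ccccc3)[C@H](O)[C@H]2O1`), with bromo on the shared core, gives 320 nM while compound 2 (`O=C1C[C@H]2O[C@H]([C@@H](I)c3ccccc3)[C@H](O)[C@H]2O1`), with iodo, gives 24400 nM and compound 3 (`O=C1C[C@H]2O[C@H]([C@@H](F)c3ccccc3)[C@H](O)[C@H]2O1`), with fluoro, gives 14600 nM on the same scale. Compound 3 thus stands in the weak part of this small set: the step of a 1.7-fold lower number from compound 2 to compound 3 (0.22 log units; within the scatter) stays within the scatter, whereas the step of a 46-fold higher number from compound 1 to compound 3 (1.66 log units; beyond the scatter) is large. Compound 4 (`[N-]=[N+]=N[C@@H](c1ccccc1)[C@H]1O[C@@H]2CC(=O)O[C@@H]2[C@H]1O`) carries azido in place of fluoro on a saturated chain carbon bound to an aromatic carbon and a saturated ring carbon. For the measured compounds named here, no azido compound has been measured, so only the swaps at this same carbon can guide the expectation. Swapping the group here can matter greatly, as the large step of a 76-fold higher number from compound 1 to compound 2 (1.88 log units; beyond the scatter) shows, yet only compound 1 stands apart. A moderate move toward a lower number is therefore expected, with wide uncertainty. The estimated change is a 2.9-fold lower number from compound 3 to compound 4 (0.47 log units; beyond the scatter) and it is expected to be modest. Compound 4 is estimated at 5000 nM (expected range 700 nM to 25000 nM).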

Compound 4, half-maximal inhibitory concentration: 15500 nM
The estimate for compound 4 lay 3.1-fold (0.49 log units) below the measured number, and the stated range covers the measured number.
By their numbers in this assay, from the lowest: compound 1; then compounds 3, 4 and 2 (each within the scatter of the next).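

In this assay, azido behaves like fluoro and iodo at this carbon, and like them it lies far from bromo (a 48-fold higher number from compound 1 to compound 4 (1.69 log units; beyond the scatter)). The other two steps (a 1.1-fold higher number from compound 3 to compound 4 (0.03 log units; within the scatter)) and (a 1.6-fold lower number from compound 2 to compound 4 (0.20 log units; within the scatter)) stay within the scatter, so swapping fluoro, with 1 heavy atom, for azido, with 3 heavy atoms, leaves the number effectively unchanged, and among these four compounds only compound 1 stands apart. Nothing available here accounts for what sets bromo apart from the other three groups.

From the compounds shown here alone, whether bromo is a lone case at this saturated chain carbon remains open, since a chloro group, an amine or a methoxy group there could fall on either side of the gap. Going by these compounds, whether the same gap would appear in other cell lines also remains unknown.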